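A few compounds are considered here, and "the series" means these few. Any claim that something is new, unique, unknown or untested is made for them only; others in the source may bear on it.

Compound 1 `Cn1cncc1CN1CC(N(CC2CCN(C(=O)NC(C)(C)C)CC2)S(=O)(=O)c2ccccn2)Cc2cc(C#N)ccc21`: 0.6 10^-6 cm/s
Compound 2 `Cc1noc(C)c1CN(C1Cc2cc(C#N)ccc2N(Cc2cncn2C)C1)S(=O)(=O)c1ccccn1`: 8 10^-6 cm/s
Compound 3 `Cn1cncc1CN1CC(N(CC2CCN(C(=O)N3CCCC3)CC2)S(=O)(=O)c2ccccn2)Cc2cc(C#N)ccc21`: 0.6 10^-6 cm/s

In an ADME assay on Caco-2 cells (Homo sapiens) for permeability, in the apical to basolateral direction (on this read-out higher numbers stand for higher permeability and lower numbers for lower permeability), compound 3 gives 0.6 10^-6 cm/s, level with compound 1 and, together with it, the lowest of the three numbers, while compound 2 at 8 10^-6 cm/s stands well apart. Compound 4 `CC(C)NC(=O)N1CCC(CN(C2Cc3cc(C#N)ccc3N(Cc3cncn3C)C2)S(=O)(=O)c2ccccn2)CC1` differs from compound 3 in one place: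

isopropylamino in place of pyrrolidin-1-yl on a carbonyl carbon

For the measured compounds named here, the only measured step that bears on this exchange is no change at the digits printed from compound 1 to compound 3 (within the scatter), where an alkylamino group on the same carbonyl carbon was replaced by pyrrolidin-1-yl without moving the number. Going back the other way to an alkylamino group is therefore expected to leave this assay unchanged, no change at the digits printed from compound 3 to compound 4 (within the scatter). For compound 4 the estimate is 0.6 10^-6 cm/s, with a range from 0.3 10^-6 cm/s to 1.2 10^-6 cm/s.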

Compound 4, apparent permeability: 0.6 10^-6 cm/s
Compound 4: the middle estimate sits on the measured number at the digits printed; measured number inside the range.
By their numbers in this assay, from the lowest: compounds 1, 3 and 4 (each within the scatter of the next); then compound 2.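

In this assay the number holds through a third group on this carbonyl carbon: no change at the digits printed from compound 3 to compound 4 (within the scatter) and no change at the digits printed from compound 1 to compound 4 (within the scatter) show that isopropylamino, with no ring and a hydrogen-bond donor, stands level with both pyrrolidin-1-yl and (tert-butyl)amino. The large gap also remains with this third group, at a 13-fold lower number from compound 2 to compound 4 (1.12 log units; beyond the scatter) when 1-(isopropylcarbamoyl)piperidin-4-yl takes the place of 3,5-dimethyl-1,2-oxazol-4-yl. Nothing at hand explains either result.
From the compounds shown here alone, whether a plain amino or methoxy group on this carbonyl carbon keeps the number level stays open. So does whether a short alkyl chain in place of 1-(isopropylcarbamoyl)piperidin-4-yl moves it toward compound 2.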